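Swapping Bromo for Fluoro in a Series Already at the Limit

The source may hold more compounds than are shown below. What is called first, only, known or untested is meant among the compounds shown, and "the series" means these compounds.

Three compounds built on a shared core, each bearing a triazole attached to an aromatic ring, have been tested in a functional assay on MCF7 cells (Homo sapiens) for cytotoxicity, read by MTT assay, with a stated time of 4 days; a higher number here means a weaker inhibitor, a lower number a stronger inhibitor. Compound 1 `C=C1C[C@]23C[C@@]1(O)CC[C@H]2c1ccc(O)c(C)c1[C@@H]3Cn1cc(-c2ccccn2)nn1` reaches only the limit of the assay, giving > 20000 nM. Compound 2 `Cc1c(O)ccc2c1[C@H](Cn1cc(-c3ccc(F)cc3)nn1)[C@@]13CC(=O)[C@@](C)(CC[C@@H]21)C3` likewise gives only a limit, > 20000 nM. Compound 3 `C=C1C[C@]23C[C@@]1(O)CC[C@@H]2c1cccc(C)c1[C@@H]3Cn1cc(-c2ccc(Br)cc2)nn1` also stops at a limit, > 20000 nM. Compound 3 therefore stands nowhere apart from the others: all three values sit at the same limit, as the limit of > 20000 nM in this assay, at which 3 of the 3 values shown sit, shows, and none can be called stronger or weaker.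

Compound 4 `C=C1C[C@]23C[C@@]1(O)CC[C@@H]2c1cccc(C)c1[C@@H]3Cn1cc(-c2ccc(F)cc2)nn1` differs from compound 3 in one place: fluoro in place of bromo on an aromatic carbon. Among the measured compounds shown here, no measured pair shows this change directly. Compound 2, which carries the same 4-fluorophenyl group on a different core, gives > 20000 nM in this assay. The expected step is a step that the limit leaves unreadable from compound 3 to compound 4, none beyond the scatter. Compound 4 is estimated at 30000 nM, within a range from 15000 nM to 100000 nM, most likely reported again only as a limit.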

Compound 4, half-maximal inhibitory concentration: > 20000 nM
Compound 4: only a limit was reported; the forecaster's own chance of this, stated with the estimate: 85%; the middle value is on the limit's open side.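

No step can be read from compound 3 to compound 4, because both stop at the same limit rather than giving a number: the limit of > 20000 nM in this assay, at which 4 of the 4 values shown sit.

The compounds shown leave open whether swapping 4-bromophenyl for 4-fluorophenyl changes the result in this assay at all.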